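The compounds below may be only part of what the source reports. "The series", "measured", "known", "first", "only" and "open" are said of these compounds alone.

Compound 1 `CCN1CCN(c2cc(C)c3cc(NC(=O)c4ccccc4F)ccc3n2)CC1` gives 32600 nM in a functional assay on MCF7 cells (Homo sapiens) for antiproliferative activity, read by MTT assay, with a stated time of 72 h; a higher number here means a weaker inhibitor, a lower number a stronger inhibitor; compound 2 `Cc1cc(N2CCN(C(C)C)CC2)nc2ccc(NC(=O)c3ccc(Cl)c(Cl)c3)cc12` gives 1710 nM.

Compound 2 stands at the lower of these two numbers, and the gap to compound 1 lies beyond the usual scatter. Compound 3 `CCN1CCN(c2cc(C)c3cc(NC(=O)c4ccc(Cl)c(Cl)c4)ccc3n2)CC1` differs from compound 2 in one place: hydrogen in place of methyl on a saturated chain carbon bound to an amine nitrogen in a ring and a saturated chain carbon. Compound 1 carries the same ethyl group yet also differs elsewhere, so this change alone has not been tested. Only a small shift is expected, none beyond the scatter. Compound 3 is therefore estimated at 2500 nM, within 1000 nM to 6500 nM. The expected step is a 1.5-fold higher number from compound 2 to compound 3 (0.16 log units; within the scatter).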

Compound 3, half-maximal inhibitory concentration: 1380 nM
Estimate against measurement, compound 3: 1.8-fold (0.26 log units) above; the range from low to high includes it.
By their numbers in this assay, from the lowest: compounds 3 and 2 (each within the scatter of the next); then compound 1.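

In this assay, going from 4-isopropylpiperazin-1-yl to 4-ethylpiperazin-1-yl gives a 1.2-fold lower number from compound 2 to compound 3 (0.09 log units; within the scatter), so this swap at this position leaves the number unchanged within the scatter. With the ethyl group held constant, 3,4-dichlorophenyl in place of 2-fluorophenyl on the carbonyl carbon gives a 24-fold lower number from compound 1 to compound 3 (1.37 log units; beyond the scatter), a large step that the first two compounds, differing in two places, could not assign to either place. No supporting data explain either step. Going by these compounds, whether a longer chain such as butyl on that piperazine nitrogen would keep the number stays open, as does the effect of a single chlorine on the phenyl ring.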